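Capping the Chain Amine of Compound 2 with a Carbamate

The source may hold more compounds than are shown below. What is called first, only, known or untested is meant among the compounds shown, and "the series" means these compounds.

Going by the values given here, compound 2 `Cc1c(C)c2c(c(C)c1OC(=O)CCCCCCCN)CCC(C)(COc1ccc(/C=C3\SC(=O)NC3=O)cc1)O2` gives 3200 nM in a functional assay on MCF7 cells (Homo sapiens) for antiproliferative activity, read by luminescence, with a stated time of 24 h (a lower number here means a stronger inhibitor, a higher number a weaker inhibitor), the lowest of the two numbers measured so far. Compound 1 `Cc1c(C)c2c(c(C)c1OC(=O)CCCC[C@@H]1SC[C@@H]3NC(=O)N[C@@H]31)CCC(C)(COc1ccc(/C=C3\SC(=O)NC3=O)cc1)O2` gives 11200 nM in this assay, and the step of a 3.5-fold lower number from compound 1 to compound 2 (0.54 log units; beyond the scatter) came from exchanging a large ring-bearing group at the chain end for a small amine. Compound 3 `Cc1c(C)c2c(c(C)c1OC(=O)CCCCCCCNC(=O)OC(C)(C)C)CCC(C)(COc1ccc(/C=C3\SC(=O)NC3=O)cc1)O2` is not yet measured; it differs from compound 2 by tert-butoxycarbonyl in place of hydrogen on an amine nitrogen. Among the compounds with values here, since the one measured step shows the number falling as the chain end became smaller, compound 3 is expected to show a modest rise, a 1.9-fold higher number from compound 2 to compound 3 (0.27 log units; within the scatter). The estimate for compound 3 is 6000 nM, within 2500 nM to 15000 nM.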

Compound 3, half-maximal inhibitory concentration: 13000 nM
For compound 3 the middle estimate is 2.2-fold (0.34 log units) below the measured one; the measured number falls inside the stated range.
By their numbers in this assay, from the lowest: compound 2; then compounds 1 and 3 (each within the scatter of the next).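

Covering the amine nitrogen with tert-butoxycarbonyl weakens the result in this assay (a 4.1-fold higher number from compound 2 to compound 3 (0.61 log units; beyond the scatter)), so this chain end responds to a change on its nitrogen. A ring-free end group can also give a number level with that of the ring-bearing group (a 1.2-fold higher number from compound 1 to compound 3 (0.06 log units; within the scatter)), so rings are not required for such a number. Nothing measured here explains either result. Going by these compounds, whether a smaller cap on the nitrogen, such as acetyl, would stay close to compound 2 remains open. On these data alone, the effect of a shorter chain carrying the same free amine is also open.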